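This account rests on a few compounds, and the source may have more. Where it says the series, first, only, none or still open, it means among the compounds named here.

Measured compounds:
- compound 1, `Cc1ccc(NS(=O)(=O)c2ccccc2)c([N+](=O)[O-])c1`: 60300 nM
- compound 2, `Cc1ccc(S(=O)(=O)Nc2ccc(C)cc2[N+](=O)[O-])cc1`: 43700 nM

Among the measured compounds shown here, in a functional assay on PC-3 cells (Homo sapiens) for cytotoxicity, read by MTT assay, with a stated time of 5 days (on this read-out lower numbers stand for stronger inhibition of growth and higher numbers for weaker inhibition of growth), compound 1 gives the highest of the two numbers measured so far; its nearest neighbour is compound 2, and the step of a 1.4-fold lower number from compound 1 to compound 2 (0.14 log units; within the scatter) stays within the scatter, so the two cannot be ordered. That step is a methyl in place of hydrogen on an aromatic carbon and leaves the nitro untouched.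

Compound 3, `Cc1ccc(NS(=O)(=O)c2ccccc2)cc1`, is not yet measured. It differs from compound 1 as follows: hydrogen in place of nitro on an aromatic carbon

For the measured compounds named here, no measured step removes or adds a nitro, so nothing speaks directly to this change, and the one step known, from compound 1 to compound 2, was within the scatter. With no guide to direction, the expected number for compound 3 in this assay is near the number of compound 1, and the step of a 1.0-fold lower number from compound 1 to compound 3 (0.00 log units; within the scatter) is expected to stay within the scatter. Compound 3 is estimated at 60000 nM, with a range from 20000 nM to 180000 nM.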

Compound 3, concentration for 50% growth inhibition: 13800 nM
Compound 3: the middle estimate sits 4.3-fold (0.64 log units) above what was measured; the whole stated range lies above it.
By their numbers in this assay, from the lowest: compound 3; then compounds 2 and 1 (each within the scatter of the next).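

Among the compounds shown here, the change from nitro to hydrogen, ortho to a large group and meta to a methyl group, gives in this assay a 4.4-fold lower number from compound 1 to compound 3 (0.64 log units; beyond the scatter) and is the first step to pass the scatter, so this position affects the read-out more than the methyl change does in a 1.4-fold lower number from compound 1 to compound 2 (0.14 log units; within the scatter) and does so modestly. At this position the nitro is not needed for growth inhibition, since the compound without it gives the lower number. Nothing available accounts for the shift.

From the compounds shown here alone, whether hydrogen is specifically favoured remains open, since an amine, a methoxy group or a chlorine at this position could place the number on either side of compound 3. Also open, going by these compounds, is whether the same change in the core of compound 2 would give a step of similar size.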